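The source may report more compounds than this note shows. Statements on the series, on what has been measured and on what is new or still open speak of the compounds shown alone.

Measured so far:
- Compound 1, `O=S(=O)(Nc1ccc2oc(-c3ccccc3)nc2c1)c1ccc(Cl)cc1`: 65000 nM
- Compound 2, `O=S(=O)(Nc1ccc2oc(-c3ccccc3)nc2c1)c1ccc(Cl)c(C(F)(F)F)c1`: 66000 nM

In an ADME assay on HEK293 cells (Homo sapiens) for cytotoxicity, read by resazurin assay, with a stated time of 48 h (a higher number here means that more compound is tolerated, a lower number that less compound is tolerated), compound 1 gives 65000 nM, and compound 2 gives 66000 nM. Among the compounds with values here, compound 1 is one of only two compounds measured, and the single measured step, a 1.0-fold higher number from compound 1 to compound 2 (0.01 log units; within the scatter), does not separate the two, so neither can be called better tolerated than the other.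

Compound 3, `CCc1ccc(S(=O)(=O)Nc2ccc3oc(-c4ccccc4)nc3c2)cc1`, is not yet measured. It differs from compound 1 in one place: ethyl in place of chloro on an aromatic carbon. Within the data shown here, no measured step swaps chloro for ethyl; the only step available, trifluoromethyl entering at another carbon of the same ring, left the number unchanged. That is weak guidance, but it gives no reason to expect movement. The step from compound 1 to compound 3 is therefore expected to stay within the scatter, as no change at the digits printed from compound 1 to compound 3 (within the scatter). Compound 3 is estimated at 65000 nM in this assay, with a range from 30000 nM to 130000 nM.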

Compound 3, half-maximal cytotoxic concentration: 81000 nM
Compound 3: the middle estimate sits 1.2-fold (0.10 log units) below what was measured, and the stated range covers the measured number.
By their numbers in this assay, from the lowest: compounds 1, 2 and 3 (each within the scatter of the next).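

In this assay, replacing the chloro group itself gives a 1.2-fold higher number from compound 1 to compound 3 (0.10 log units; within the scatter) and so does not separate the two compounds. The earlier step added trifluoromethyl at another carbon and left chloro in place, whereas this one changes the group on the aromatic carbon para to a large group, with the one heavy atom of chloro giving way to the two of ethyl. For these compounds, then, neither the swap of chloro for ethyl nor the earlier addition moves the number beyond the scatter, and no measured evidence bears on why. As far as these compounds go, whether an amine, a carboxylic acid or a longer chain at this carbon would also stay within the scatter remains open. So does the effect of changes elsewhere on the shared core.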